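The compounds below may be only part of what the source reports. "The series", "measured", "known", "first", "only" and "open" are said of these compounds alone.

Compound 1 `CCCn1c(=O)c2nc(C(C)(C)CCC)[nH]c2n(CCC)c1=O` was tested in an assay on cell membranes for binding affinity to adenosine receptor A1 (Cavia porcellus), read by radioligand binding (a higher number here means a weaker inhibitor, a lower number a stronger inhibitor), where compound 1 gives 25 nM. Two compounds built on a different core were measured alongside it: compound 2 `CC(C)(C)CNc1ncnc2c1ncn2C1O[C@H](CO)[C@@H](O)[C@H]1O` gives 17 nM, and compound 3 `CCC(CC)Nc1ncnc2c1ncn2C1O[C@H](CO)[C@@H](O)[C@H]1O` gives 0.75 nM. Among these three numbers compound 1 has the highest; compound 2 sits so close that the gap lies within the usual scatter and no order between the two can be claimed, whereas compound 3 lies clearly lower, beyond the scatter. Among the measured compounds shown here, the one step between compounds that differ in a single place is a 23-fold lower number from compound 2 to compound 3 (1.36 log units; beyond the scatter).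

Compound 4 `CCCn1c(=O)c2nc(CC3CC3)[nH]c2n(CCC)c1=O` differs from compound 1 in one place: cyclopropylmethyl in place of 1,1-dimethylbutyl on an aromatic carbon. For the measured compounds named here, the only measured step bears on this change just loosely, since it concerns another core and a nitrogen rather than an aromatic carbon; it shows that exchanging one branched alkyl group for another can move the number a great deal, but it gives no direction for the present swap. With no closer guide, a modest change beyond the scatter, toward a higher number, is the expectation for compound 4, a 2.4-fold higher number from compound 1 to compound 4 (0.38 log units; beyond the scatter). Compound 4 is therefore estimated at 60 nM, with a range from 15 nM to 250 nM.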

Compound 4, inhibition constant: 120 nM
Compound 4: the middle estimate sits 2.0-fold (0.30 log units) below what was measured; low and high end bracket the measured number.
By their numbers in this assay, from the lowest: compound 3; then compounds 2 and 1 (each within the scatter of the next); then compound 4.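

Among the compounds shown here, on the core of compound 1, the group on the aromatic carbon between two ring nitrogen atoms affects the number in this assay: cyclopropylmethyl in place of 1,1-dimethylbutyl gives a 4.8-fold higher number from compound 1 to compound 4 (0.68 log units; beyond the scatter), the only measured step at this position. Both groups contain only carbon and have no hydrogen-bond donors or acceptors, so the step compares two hydrocarbon groups, but it combines two differences, a smaller count of heavy atoms and the arrival of a three-membered ring, and a single pair cannot separate them. Nothing measured here explains why the number moves in this direction.

On these data alone, what remains open is whether the step follows the loss of heavy atoms or the presence of the ring, a question that a straight butyl chain or a cyclobutyl ring at this position could help to settle. As far as these compounds go, the effect of a group carrying an amine or a carboxylic acid here also remains open, as does how changes elsewhere on the shared core would affect the number.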